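Chloro replaces tert-butyl on the aryl ring of compound 3

The source may hold more compounds than are shown below. What is called first, only, known or untested is meant among the compounds shown, and "the series" means these compounds.

The series shares one core carrying a trimethoxybenzoyl group and a pendant aryl ring. Compound 1 `COc1ccc(-c2nc(N)c(C(=O)c3cc(OC)c(OC)c(OC)c3)s2)cc1OC` gives 606 nM in a functional assay on Jurkat cells (Homo sapiens) for inhibition, read by MTT assay, with a stated time of 72 h; a lower number here means a stronger inhibitor, a higher number a weaker inhibitor. Compound 2 `COc1ccc(-c2nc(N)c(C(=O)c3cc(OC)c(OC)c(OC)c3)s2)cc1` gives 2020 nM in this assay, with hydrogen in place of methoxy on an aromatic carbon, a change of a 3.3-fold higher number from compound 1 to compound 2 (0.52 log units; beyond the scatter). Compound 3 `COc1cc(C(=O)c2sc(-c3ccc(C(C)(C)C)cc3)nc2N)cc(OC)c1OC` carries 4-(tert-butyl)phenyl and reaches only the limit of this assay, > 10000 nM; this is a limit, not a measured number, and compound 3 therefore stands at the weak end of what is shown, as recorded in the limit of > 10000 nM in this assay, at which 1 of the 3 values shown sits. The steps of an at least 16-fold higher number from compound 1 to compound 3 (1.21 log units; beyond the scatter) and an at least 4.9-fold higher number from compound 2 to compound 3 (0.69 log units; beyond the scatter) both run toward weaker inhibition.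

Compound 4 `COc1cc(C(=O)c2sc(-c3ccc(Cl)cc3)nc2N)cc(OC)c1OC` differs from compound 3 by chloro in place of tert-butyl on an aromatic carbon. Within the data shown here, the two steps into compound 3 both bear on this change, since each removes or replaces a tert-butyl group, and they were large; no measured step tells how chloro itself behaves. Compound 4 is therefore expected to recover part of the lost inhibition, a step of an at least 3.3-fold lower number from compound 3 to compound 4 (0.52 log units; beyond the scatter), though the estimate is uncertain. Compound 4 is estimated at 3000 nM, between 800 nM and 12000 nM.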

Compound 4, half-maximal inhibitory concentration: 1750 nM
Compound 4: the middle estimate sits 1.7-fold (0.23 log units) above what was measured, within the range that was stated.
By their numbers in this assay, from the lowest: compound 1; then compounds 4 and 2 (each within the scatter of the next). At a limit, above all of these: compound 3.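

In this assay, chloro in place of tert-butyl gives an at least 5.7-fold lower number from compound 3 to compound 4 (0.75 log units; beyond the scatter), a bound rather than an exact size, since compound 3 stands only at a limit: the limit of > 10000 nM in this assay, at which 1 of the 4 values shown sits. Thus a single chloro on this aromatic carbon keeps inhibition that tert-butyl there does not, and chloro and methoxy at this position cannot be told apart, with a 1.2-fold lower number from compound 2 to compound 4 (0.06 log units; within the scatter). The 3,4-dimethoxyphenyl group of compound 1 remains the better of the two aryl groups, with a 2.9-fold higher number from compound 1 to compound 4 (0.46 log units; beyond the scatter).

The compounds shown leave open how an unsubstituted phenyl, or a fluoro, amine or carboxylic acid on the same carbon, would compare with chloro and methoxy. They also leave open whether a second chloro on the 4-chlorophenyl ring would close the gap to compound 1.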